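Aryl Substitution at the Core: Thiophen-3-yl Replacing 4-Hydroxyphenyl

This account rests on a few compounds, and the source may have more. Where it says the series, first, only, none or still open, it means among the compounds named here.

Measured compounds:
- compound 1 `Cn1nccc1-c1ncnc2c1ncn2C1O[C@H](CO)[C@@H](O)[C@H]1O`: "not active" (no number reported) in a functional assay on CCRF-CEM cells (Homo sapiens) for inhibition; on this read-out lower numbers stand for stronger inhibition and higher numbers for weaker inhibition
- compound 2 `OC[C@H]1OC(n2cnc3c(-c4ccccn4)ncnc32)[C@H](O)[C@@H]1O`: 900 nM
- compound 3 `OC[C@H]1OC(n2cnc3c(-c4ccc(O)cc4)ncnc32)[C@H](O)[C@@H]1O`: 1250 nM

Compound 1 gives no number in this assay, only a report of no activity. Compound 2 and compound 3 both give numbers, and in this assay compound 3 gives the higher of the two. Among the measured compounds shown here, the only single-point step among the measured compounds, a 1.4-fold higher number from compound 2 to compound 3 (0.14 log units; within the scatter), comes with the exchange of pyridin-2-yl for 4-hydroxyphenyl on the same aromatic carbon; it falls within the scatter, so the two compounds are treated as equivalent on this read-out.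

Compound 4 `OC[C@H]1OC(n2cnc3c(-c4ccsc4)ncnc32)[C@H](O)[C@@H]1O` is not yet measured. The change from compound 3 is thiophen-3-yl in place of 4-hydroxyphenyl on an aromatic carbon. The step from compound 2 to compound 3 is the only measured one touching this position, and it shows that swapping one aromatic group for another there left the number essentially unchanged. Compound 1 shows that a pyrazolyl group at the same position gives no measurable activity, so not every aromatic group is tolerated.

On this basis compound 4 is expected to stay close to compound 3, a step of a 1.1-fold lower number from compound 3 to compound 4 (0.06 log units; within the scatter), with no change expected beyond the scatter. The estimate for compound 4 in this assay is 1100 nM, within a range from 400 nM to 3500 nM.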

Compound 4, half-maximal inhibitory concentration: 1640 nM
Compound 4: the middle estimate sits 1.5-fold (0.17 log units) below what was measured; low and high end bracket the measured number.
By their numbers in this assay, from the lowest: compounds 2, 3 and 4 (each within the scatter of the next).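

In this assay a five-membered aromatic ring with sulfur now sits on this carbon of the shared core with a number in the same band, as a 1.3-fold higher number from compound 3 to compound 4 (0.12 log units; within the scatter) and a 1.8-fold higher number from compound 2 to compound 4 (0.26 log units; within the scatter) are both read as no change, so thiophen-3-yl, 4-hydroxyphenyl and pyridin-2-yl cannot be told apart here, and the hydroxyl donor of 4-hydroxyphenyl is not needed to keep that number. Ring size alone does not decide the outcome, since compound 1, which also carries a five-membered aromatic group, gives "not active" (no number reported) in this assay and its steps to the other compounds cannot be read. Nothing on hand accounts for the flat numbers or for the report on compound 1.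

Still open, going by these compounds, is how a non-aromatic group on this carbon would read, for instance an amine, a carboxylic acid or a longer alkyl chain. Also open, on these data alone, is whether substituents on the thiophene ring, such as a methyl or a chlorine, would move the number beyond the scatter, and whether the methyl on the pyrazole of compound 1 or the pyrazole itself goes with the missing activity.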